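Replacing the bicyclic group of compound 3 in the triazole set

The compounds below may be only part of what the source reports. "The series", "measured", "known", "first", "only" and "open" are said of these compounds alone.

compound 1 `COc1n[nH]c2ncc(-c3ncc(-c4c(F)ccc(NS(=O)(=O)c5cccc(Cl)c5)c4F)[nH]3)cc12`: 983 nM
compound 2 `COc1n[nH]c2ncc(-c3nc(-c4c(F)ccc(NS(=O)(=O)c5cccc(Cl)c5)c4F)no3)cc12`: 29 nM
compound 3 `COc1n[nH]c2ncc(-c3cn(-c4c(F)ccc(NS(=O)(=O)c5cccc(Cl)c5)c4F)nn3)cc12`: 1.9 nM

The three measured compounds share both outer parts and differ in the five-membered ring that links them. In an assay on Sf9 cells for inhibition of mitogen-activated protein kinase kinase kinase 20 (Homo sapiens), read by ADP-Glo, with a stated time of 30 min (on this read-out higher numbers stand for weaker inhibition and lower numbers for stronger inhibition), compound 3 has the lowest number of the three; its gap to compound 2 and its gap to compound 1 are both beyond the scatter, so compound 3 is the most potent of the set as it stands. Compound 4 `Nc1ncc(-c2cn(-c3c(F)ccc(NS(=O)(=O)c4cccc(Cl)c4)c3F)nn2)cn1` keeps the five-membered aromatic ring with 3 nitrogen of compound 3 together with everything on the far side of it and changes only the group on the other ring carbon: a group of 7 heavy atoms (4 carbon, 3 nitrogen; one six-membered aromatic ring with 2 hetero atoms) in place of a group of 11 heavy atoms (7 carbon, 3 nitrogen, 1 oxygen; one five-membered aromatic ring with 2 hetero atoms, one six-membered aromatic ring with 1 hetero atom), on an aromatic carbon. Among the compounds with values here, no measured pair shows a change of this kind, so nothing in the set calibrates it directly. A smaller group replaces a larger one on the same carbon, and the expectation is a moderate loss, beyond the scatter, toward weaker inhibition. The number expected for compound 4 is 15 nM, with a range from 3 nM to 100 nM. This estimate means an expected step of a 7.9-fold higher number from compound 3 to compound 4 (0.90 log units; beyond the scatter).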

Compound 4, half-maximal inhibitory concentration: 8.9 nM
For compound 4 the middle estimate is 1.7-fold (0.23 log units) above the measured one; the range from low to high includes it.
By their numbers in this assay, from the lowest: compound 3; then compound 4; then compound 2; then compound 1.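

In this assay, the aromatic carbon of the five-membered aromatic ring with 3 nitrogen accepts a much smaller group than the two-ring group of compound 3: 2-aminopyrimidin-5-yl gives a 4.7-fold higher number from compound 3 to compound 4 (0.67 log units; beyond the scatter), a modest loss. Within the data shown here, the earlier compounds varied only the linking ring, so this is the first reading of how this outer group affects the number while that ring stays fixed. Both groups have the same counts of hydrogen-bond donors and acceptors, and no measurement here explains the size of the step.

As far as these compounds go, it remains open whether the amine of 2-aminopyrimidin-5-yl is needed at this carbon; a plain pyrimidin-5-yl or a 2-methoxypyrimidin-5-yl would test that. From the compounds shown here alone, the effect of 2-aminopyrimidin-5-yl on the other linking rings also remains open.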